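Second Chloro on the Core of Compound 2

The source may report more compounds than this note shows. Statements on the series, on what has been measured and on what is new or still open speak of the compounds shown alone.

Compound 1 `ClCc1ccccc1Cn1cnc2c(Cl)ncnc21` gives 2340 nM in a functional assay on RXF 393 cells (Homo sapiens) for cytotoxicity, read by sulforhodamine B assay, with a stated time of 48 h; a higher number here means a weaker inhibitor of growth, a lower number a stronger inhibitor of growth.
Compound 2 `ClCc1cccc(Cn2cnc3ncnc(Cl)c32)c1` gives 17400 nM in this assay.

Compound 2 stands highest of the two measured numbers in this assay; its gap to compound 1 lies beyond the scatter. Compound 3 `ClCc1cccc(Cn2cnc3nc(Cl)nc(Cl)c32)c1` differs from compound 2 by chloro in place of hydrogen on an aromatic carbon. Among the compounds with values here, no measured pair shows this change, so nothing is known about its effect. The step from compound 2 to compound 3 is expected to stay within the scatter, in no clear direction, at a 1.2-fold lower number from compound 2 to compound 3 (0.06 log units; within the scatter). Compound 3 is therefore expected near 15000 nM, within a range from 5000 nM to 45000 nM.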

Compound 3, concentration for total growth inhibition: 2630 nM
Compound 3: middle estimate off by 5.7-fold (0.76 log units), on the high side, outside the stated range (below it).
By their numbers in this assay, from the lowest: compounds 1 and 3 (each within the scatter of the next); then compound 2.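

In this assay, chloro in place of hydrogen on the aromatic carbon between two ring nitrogen atoms gives a 6.6-fold lower number from compound 2 to compound 3 (0.82 log units; beyond the scatter) and so shows that this position of the core can move growth inhibition beyond the scatter. Within the data shown here, the step is the only reading of this change, and nothing at hand accounts for it.

Going by these compounds, whether an amine or a methoxy group on this carbon would give a similar step remains open. So does whether the same chloro would act alike on the core of compound 1.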